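Lipophilicity notes: from compound 2 to compound 3

This account rests on a few compounds, and the source may have more. Where it says the series, first, only, none or still open, it means among the compounds named here.

Measured in a physicochemical assay for lipophilicity, read by HPLC, at pH 7.5 (a higher number here means a more lipophilic compound, a lower number a more polar compound), so far:
- compound 1 `CC[C@@H](Nc1c(C#N)c(-c2ccc(-c3cccc(C)c3F)cc2)nc2cnccc12)C(N)=O` gives 3
- compound 2 `CC[C@@H](Nc1c(C#N)c(-c2ccc(-c3cccc(Cl)c3F)cc2)nc2cnccc12)C(N)=O` gives 3.1

Compound 2 stands at 3.1 in this assay, and its value lies within the scatter of the value for compound 1.

The next change leads to compound 3 `CC[C@@H](Nc1c(C#N)c(-c2ccc(-c3cnccc3C)cc2)nc2cnccc12)C(N)=O` and is 4-methylpyridin-3-yl in place of 3-chloro-2-fluorophenyl on an aromatic carbon. In words, it is 4-methylpyridin-3-yl in place of 3-chloro-2-fluorophenyl, on an aromatic carbon of a six-membered aromatic ring of carbon only, para to a large group.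

Within the data shown here, only one measured step bears on this. That step, a number 0.10 log units higher from compound 1 to compound 2 (within the scatter), is chloro in place of methyl on an aromatic carbon. It exchanges one group on a ring of carbon only and stays within the scatter, so it says little here. Among the measured compounds shown here, no measured step replaces such a ring with one holding a hetero atom, and the expectation rests mainly on the structural change. The expected step is a number 1.00 log units lower from compound 2 to compound 3 (beyond the scatter), downward and beyond the scatter. For compound 3 the estimated value is 2.1, with an expected range from 1.6 to 2.6 as its bounds.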

Compound 3, distribution coefficient: 2
Compound 3: middle estimate off by 0.10 log units, on the high side; low and high end bracket the measured number.
By their numbers in this assay, from the lowest: compound 3; then compounds 1 and 2 (each within the scatter of the next).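

In this assay, this position, on an aromatic carbon of a six-membered aromatic ring of carbon only, para to a large group, answers clearly to an exchange of the whole ring: the outcome is a number 1.10 log units lower from compound 2 to compound 3 (beyond the scatter), and likewise a number 1.00 log units lower from compound 1 to compound 3 (beyond the scatter), whereas the substituent swap alone gave a number 0.10 log units higher from compound 1 to compound 2 (within the scatter). The drop therefore appears from both phenyl starting points, but each exchange alters several features at once, with the ring nitrogen entering as the fluorine and either the chlorine or the methyl leave, and 4-methylpyridin-3-yl also differs in where its methyl sits. No supporting measurement is available to give a cause for the size of these steps.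

The compounds shown leave open how the step divides between the ring nitrogen and the departing substituents, a question that a 4-methylphenyl group at the same place would help to separate. Also open, on these data alone, is how this assay would read with a pyrimidine ring here, or with an amine or a carboxylic acid carried on the entering ring.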